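This account rests on a few compounds, and the source may have more. Where it says the series, first, only, none or still open, it means among the compounds named here.

Compound 1 `COc1ccc(-c2cc(/C=C/C(=O)c3ccc(N)cc3)[nH]n2)cc1`: 98%
Compound 2 `COc1cc(-c2cc(/C=C/C(=O)c3ccc(N)cc3)[nH]n2)cc(OC)c1OC`: 92%
Compound 3 `COc1cc(-c2cc(/C=C/C(=O)c3ccc(F)c(F)c3)[nH]n2)cc(OC)c1OC`: 100%

In a functional assay on SF-539 cells (Homo sapiens) for cytotoxicity, read by sulforhodamine B assay, with a stated time of 48 h, tested at 0.01 uM (a higher number here means a weaker effect of the compound at the concentration tested, a lower number a stronger effect), compound 2 gives 92%, the lowest of the three numbers, although compound 1 at 98% and compound 3 at 100% both lie within the scatter of it. Compound 4 `COc1ccc(-c2cc(/C=C/C(=O)c3ccc(N)cc3)[nH]n2)cc1OC` differs from compound 2 by hydrogen in place of methoxy on an aromatic carbon. Among the compounds with values here, the only measured step, a number 8 percentage points higher from compound 2 to compound 3 (within the scatter), alters a different part of the molecule and stays within the scatter, and no measured pair shows hydrogen in place of methoxy at this position. Nothing in the data therefore points to a change beyond the scatter. Compound 4 is expected to give about 92%, between 82% and 100%. The step of no change at the digits printed from compound 2 to compound 4 (within the scatter) is estimated to stay within the scatter.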

Compound 4, a percentage reported as activity, at one concentration (the size of the read-out at that concentration, not a potency): 93%
The estimate for compound 4 lay 1 percentage points below the measured number; the range from low to high includes it.
By their numbers in this assay, from the lowest: compounds 2, 4, 1 and 3 (each within the scatter of the next).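

In this assay the methoxy on this aromatic carbon can now be read in both directions: hydrogen in its place gives a number 1 percentage points higher from compound 2 to compound 4 (within the scatter), and methoxy in place of hydrogen on the ring of compound 1 gives a number 5 percentage points lower from compound 1 to compound 4 (within the scatter). Neither change moves the read-out beyond the scatter at the one concentration tested. No evidence is available on why this is so. The compounds shown leave open whether a hydroxyl or an amine on this carbon would behave as hydrogen and methoxy do, and whether these steps would stay within the scatter at higher concentrations.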